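Swapping the Para Group on an Anilino Quinazolinedione Core

A few compounds are considered here, and "the series" means these few. Any claim that something is new, unique, unknown or untested is made for them only; others in the source may bear on it.

Measured compounds:
- compound 1, `O=C1C(Nc2ccc(CO)cc2)=CC(=O)c2ncncc21`: 1000 nM
- compound 2, `O=C1C(Nc2cccc(B(O)O)c2)=CC(=O)c2ncncc21`: 9000 nM
- compound 3, `O=C1C=CC(=O)c2ncncc21`: 18000 nM

The three compounds were tested in a functional assay on PANC-1 cells (Homo sapiens) for cytotoxicity, read by MTT assay, with a stated time of 72 h; on this read-out higher numbers stand for weaker inhibition and lower numbers for stronger inhibition. Compound 3, the bare shared core, gives 18000 nM, the highest number of the three. Attaching an anilino group to that core changes the picture: compound 2, with a boronic acid on the ring, gives 9000 nM, and compound 1, with a hydroxymethyl group, gives 1000 nM, the lowest number here. Compound 1 stands well apart from both neighbours, and each of those gaps lies beyond the usual scatter of repeated measurements.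

Compound 4, `CCOC(=O)c1ccc(NC2=CC(=O)c3ncncc3C2=O)cc1`, has not yet been measured in this assay. It differs from compound 1 in one place: ethoxycarbonyl in place of hydroxymethyl on an aromatic carbon. The group that leaves and the group that enters occupy the same spot on the ring, so the anilino linkage that separates compound 1 from compound 3 is kept. Without any single-change step between measured compounds to lean on, the expectation is a small step, if any, toward a higher number, staying within the scatter; compound 4 is expected to move from compound 1 by a 1.5-fold higher number from compound 1 to compound 4 (0.18 log units; within the scatter). The estimate for compound 4 is 1500 nM, expected to fall between 400 nM and 6000 nM.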

Compound 4, half-maximal inhibitory concentration: 1600 nM
Compound 4: middle estimate off by 1.1-fold (0.03 log units), on the low side, and the stated range covers the measured number.
By their numbers in this assay, from the lowest: compounds 1 and 4 (each within the scatter of the next); then compounds 2 and 3 (each within the scatter of the next).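

In this assay, putting ethoxycarbonyl in place of hydroxymethyl on an aromatic carbon, para to a large group, gives a 1.6-fold higher number from compound 1 to compound 4 (0.20 log units; within the scatter), so this swap leaves the two compounds indistinguishable on this read-out. For the compounds shown here, this is the first comparison in the set in which only one place differs, and it shows that this position can carry very different groups without a change beyond the scatter: hydroxymethyl has 2 heavy atoms and 1 hydrogen-bond donor, whereas ethoxycarbonyl has 5 heavy atoms and 0 hydrogen-bond donors. No measurement shown here offers an explanation for this result.

From the compounds shown here alone, both groups compared at this position contain oxygen and neither carries a charge, so it remains open whether an amine, a carboxylic acid or a plain longer carbon chain at the same spot would give a similar number. A single step also cannot show how much larger the group can become, or whether the same swap would give a similar result on a different core.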